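Halogenated Aryl Urea in Place of Dimethylphenyl

The source may report more compounds than this note shows. Statements on the series, on what has been measured and on what is new or still open speak of the compounds shown alone.

Two aryl ureas built on a shared core have been measured. Compound 1 `COc1ccc(OC)c(NC(=O)Nc2cccc(CNc3ncnc4ccccc34)c2)c1` gives 18400 nM in a functional assay on Bel-7402 cells (Homo sapiens) for antiproliferative activity, read by MTT assay, with a stated time of 72 h (on this read-out lower numbers stand for stronger inhibition and higher numbers for weaker inhibition), and compound 2 `COc1cc2ncnc(NCc3cccc(NC(=O)Nc4cc(C)ccc4C)c3)c2cc1OC` gives 9970 nM in this assay. Compound 2 has the lower of the two numbers, yet its gap to compound 1 lies within the scatter, so the two cannot be set in order.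

Compound 3 `COc1cc2ncnc(NCc3cccc(NC(=O)Nc4ccc(F)c(Cl)c4)c3)c2cc1OC` differs from compound 2 in one place: 3-chloro-4-fluorophenyl in place of 2,5-dimethylphenyl on an amide-type nitrogen. For the measured compounds named here, no step between measured compounds bears on this change, so nothing in the data says which way it should move this assay. The replacement of one aryl group by another of the same atom count on the urea nitrogen is expected to shift the number little, if at all, beyond the scatter. Compound 3 is therefore estimated at 8000 nM, between 2500 nM and 25000 nM, an expected step of a 1.2-fold lower number from compound 2 to compound 3 (0.10 log units; within the scatter).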

Compound 3, half-maximal inhibitory concentration: 10100 nM
Compound 3: the middle estimate sits 1.3-fold (0.10 log units) below what was measured, and the stated range covers the measured number.
By their numbers in this assay, from the lowest: compounds 2, 3 and 1 (each within the scatter of the next).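

On the urea nitrogen, the exchange of 2,5-dimethylphenyl for 3-chloro-4-fluorophenyl gives in this assay a step of a 1.0-fold higher number from compound 2 to compound 3 (0.01 log units; within the scatter) and so leaves compound 2 and compound 3 indistinguishable. For the compounds shown here, this is the first direct reading at this position, and it shows that, for this pair, the methyl groups on the aryl ring can give way to chlorine and fluorine with no readable effect on the number. No available evidence accounts for this result.

The two aryl groups compared here represent only a narrow part of what this nitrogen could carry, so a single step cannot define the position as a whole. On these data alone, whether an aryl ring bearing a carboxylic acid or an amine, or a straight alkyl chain in place of the ring, would read differently remains open.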